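From Compound 2 to Compound 3: A Longer Side Chain

This account rests on a few compounds, and the source may have more. Where it says the series, first, only, none or still open, it means among the compounds named here.

- compound 1 `COCCOc1cc2ncnc(-n3nc(-c4ccccn4)nc3N)c2cc1OCCOC` with a half-life of 2.4 h
- compound 2 `COCCOc1cc2c(-n3nc(-c4ccccn4)nc3N)ncnc2cc1OC` with a half-life of 2 h

In an ADME assay on liver (Mus musculus, strain CD-1) for metabolic stability, read by HPLC, using microsomes (a higher number here means that the compound lasts longer, a lower number that the compound disappears faster), compound 2 gives 2 h and compound 1 gives 2.4 h, two values within the scatter of each other. Compound 3 `COc1cc2ncnc(-n3nc(-c4ccccn4)nc3N)c2cc1OCCCNC(=O)OC(C)C` has not yet been measured. It differs from compound 2 as follows: ((isopropoxycarbonyl)amino)methyl in place of methoxy on a saturated chain carbon, two bonds along the chain from an oxygen on an aromatic ring. In words, ((isopropoxycarbonyl)amino)methyl stands in place of methoxy on a saturated chain carbon, two bonds along the chain from an oxygen on an aromatic ring.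

Going by the values given here, only one measured step bears on this change: a 1.2-fold lower number from compound 1 to compound 2 (0.08 log units; within the scatter), with hydrogen in place of methoxymethyl on a saturated chain carbon bound to an oxygen on an aromatic ring. Among the compounds with values here, that step removes a group, while compound 3 gains a larger one, and no measured compound carries the entering group. Within the data shown here, the data therefore give only weak guidance on direction, and a small fall is expected, with no step clearly beyond the scatter. The expected change is a 1.3-fold lower number from compound 2 to compound 3 (0.12 log units; within the scatter) in this assay. For compound 3 the half-life is estimated at 1.5 h, within an expected range of 0.6 h to 3 h, pending measurement.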

Compound 3, half-life: 0.2 h
For compound 3 the middle estimate is 7.5-fold (0.88 log units) above the measured one; measured number below the stated range.
By their numbers in this assay, from the lowest: compound 3; then compounds 2 and 1 (each within the scatter of the next).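

In this assay, going by these compounds alone, this position proves far from indifferent to what it carries: the exchange gives a 10-fold lower number from compound 2 to compound 3 (1.00 log units; beyond the scatter) and lies beyond the scatter, whereas the only earlier step on this kind of side chain, a 1.2-fold lower number from compound 1 to compound 2 (0.08 log units; within the scatter), stayed within it. The earlier pair showed that shortening or removing a small ether chain left the half-life within the scatter, while this result shows that the same stretch of chain can also accompany a steep loss once 2-methoxyethoxy gives way to 3-((isopropoxycarbonyl)amino)propoxy. Nothing measured here bears on why the half-life falls so sharply.

Within the data shown here, the single step cannot separate the longer chain from the isopropoxycarbonyl group and the amide hydrogen that enter with it, so the whole exchange is all that can be tied to the result. From the compounds shown here alone, whether the loss stays with a plain 3-methoxypropoxy chain, or with a free amine or an acetyl amide at the end of the same propoxy chain, remains open.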